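Compound 1 and Its Double-Bond Isomer, Compound 4

This account rests on a few compounds, and the source may have more. Where it says the series, first, only, none or still open, it means among the compounds named here.

In a physicochemical assay for lipophilicity, measured as octanol-water partition (a lower number here means a more polar compound, a higher number a more lipophilic compound), compound 1 `COC(=O)c1cn(C/C=C(/C)CC/C=C(\C)CCC=C(C)C)nn1` gives 5.25, the second highest of the three numbers measured. Compound 2 `CCCCCc1cn(C/C=C(/C)CC/C=C(\C)CCC=C(C)C)nn1` stands higher at 7.5, and compound 3 `COC(=O)c1cn(CC=C(C)C)nn1` lower at 1.3. Compound 4 `COC(=O)c1cn(C/C=C(\C)CC/C=C(\C)CCC=C(C)C)nn1` differs from compound 1 in configuration only: the two compounds have the same atoms and bonds and differ only in configuration as drawn: 1 of 2 stereo elements differ; a double bond is drawn Z in compound 1 and E in compound 4. Among the compounds with values here, the one measured step, a number 2.25 log units higher from compound 1 to compound 2 (beyond the scatter), is large, but it puts pentyl in place of methoxycarbonyl and leaves configuration untouched, so it bears only indirectly. Within the data shown here, no measured pair differs in configuration alone. Compound 1 at 5.25 is therefore the best guide, and no step beyond the scatter is expected in this assay, in either direction. The expected step is no change at the digits printed from compound 1 to compound 4 (within the scatter). Compound 4 is estimated at 5.25, with an expected range from 4.95 to 5.55.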

Compound 4, partition coefficient: 5.25
Compound 4: the middle estimate sits on the measured number at the digits printed; the measured number falls inside the stated range.
By their numbers in this assay, from the lowest: compound 3; then compounds 1 and 4 (each within the scatter of the next); then compound 2.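

In this assay, this pair gives a direct reading of configuration at this double bond, with no change at the digits printed from compound 1 to compound 4 (within the scatter). Within the data shown here, the earlier compounds held configuration fixed, and their one step concerned pentyl in place of methoxycarbonyl. Here, drawing the double bond Z or E leaves the number within the scatter, and the comparison isolates that single change: the fact that compounds 1 and 4 differ only in the configuration as drawn

Going by these compounds, whether the same holds when a carboxylic acid or an amide stands in place of methoxycarbonyl remains open. So does the effect of changing the other double bond, which is drawn alike in compound 1 and compound 4.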